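This account rests on a few compounds, and the source may have more. Where it says the series, first, only, none or still open, it means among the compounds named here.

Compound 2, `COc1cc(-c2nn(-c3cccc(NC(=O)c4ccccc4)c3)cc2-c2ccncc2)ccc1Cl`, is the plain benzamide of the pair. In a functional assay on KM12 cells (Homo sapiens) for inhibition, read by sulforhodamine B assay, with a stated time of 48 h (a lower number here means a stronger inhibitor of growth, a higher number a weaker inhibitor of growth), compound 2 gives only a limit, > 100000 nM. Compound 1, `COc1cc(-c2nn(-c3cccc(NC(=O)c4cccc(C(F)(F)F)c4)c3)cc2-c2ccncc2)ccc1Cl`, carries a trifluoromethyl on an aromatic carbon where compound 2 has hydrogen. In this assay compound 1 likewise gives only a limit, > 50000 nM. Going by the values given here, the single step across measured compounds, a step that the two limits leave unreadable from compound 1 to compound 2, cannot be read in size, since both ends sit at limits (the limit of > 100000 nM in this assay, at which 1 of the 2 values shown sits, (the limit of > 50000 nM in this assay, at which 1 of the 2 values shown sits)). Compound 3, `COc1cc(-c2nn(-c3cccc(NC(=O)Nc4ccc(Cl)c(Cl)c4)c3)cc2-c2ccncc2)ccc1Cl`, carries (3,4-dichlorophenyl)amino in place of phenyl on a carbonyl carbon. Among the compounds with values here, no measured step touches this change, so the series sets neither its size nor its direction; the two limits show only that the benzamido pattern on the shared core has given no readable growth inhibition. For compound 3 the estimate stays close to the limit, leaving room for a move toward stronger inhibition, with an expected step of an at least 3.3-fold lower number from compound 2 to compound 3 (0.52 log units; beyond the scatter). The estimated value for compound 3 is 30000 nM, ranging from 3000 nM to 100000 nM.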

Compound 3, concentration for total growth inhibition: 2770 nM
Estimate against measurement, compound 3: 11-fold (1.03 log units) above; the measured number lies below the stated range.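

In this assay, (3,4-dichlorophenyl)amino on the carbonyl carbon gives the first readable growth inhibition among the compounds shown, with an at least 36-fold lower number from compound 2 to compound 3 (1.55 log units; beyond the scatter) and an at least 18-fold lower number from compound 1 to compound 3 (1.25 log units; beyond the scatter). Compound 2 remains a limit and not a number: the limit of > 100000 nM in this assay, at which 1 of the 3 values shown sits. Compound 1 also remains a limit and not a number: the limit of > 50000 nM in this assay, at which 1 of the 3 values shown sits.

The change brings in the amino nitrogen and the two chlorines together, and the compounds shown do not separate the contribution of each. Open questions are whether plain phenylamino on the same carbonyl carbon already gives a readable value, and whether the ring can be replaced, as in cyclohexylamino.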